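Swapping quinolinyl for benzofuranyl on the amide

This account rests on a few compounds, and the source may have more. Where it says the series, first, only, none or still open, it means among the compounds named here.

Compounds measured so far:
- Compound 1 `CN1[C@@H]2c3[nH]c4ccccc4c3C[C@H]1[C@H](C#N)N1[C@@H](CNC(=O)c3ccc(F)cc3)c3[nH]c4ccccc4c3C[C@@H]21`: 210 nM
- Compound 2 `CN1[C@@H]2c3[nH]c4ccccc4c3C[C@H]1[C@H](C#N)N1[C@@H](CNC(=O)c3ccc4ccccc4n3)c3[nH]c4ccccc4c3C[C@@H]21`: 110 nM

Both compounds share one core and differ only in the aromatic group attached to the amide carbonyl. In a functional assay on HepG2 cells (Homo sapiens) for cytotoxicity, read by MTT assay, with a stated time of 72 h (on this read-out lower numbers stand for stronger inhibition and higher numbers for weaker inhibition), compound 1 gives 210 nM, while compound 2 gives 110 nM. The step of a 1.9-fold lower number from compound 1 to compound 2 (0.28 log units; within the scatter) is the only one on record, and it does not rise above the scatter of repeated measurements, so compound 2 and compound 1 cannot be told apart on these numbers.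

Compound 3 `CN1[C@@H]2c3[nH]c4ccccc4c3C[C@H]1[C@H](C#N)N1[C@@H](CNC(=O)c3cc4ccccc4o3)c3[nH]c4ccccc4c3C[C@@H]21` has not yet been measured. It differs from compound 2 in one place: 1-benzofuran-2-yl in place of quinolin-2-yl on a carbonyl carbon. Going by the values given here, the one measured step bears on this change only loosely, as it also exchanged one aromatic group for another on the same carbonyl carbon and left the read-out essentially unchanged. With nothing showing that the identity of this aromatic group moves the number, the expected step for compound 3 is a 1.4-fold higher number from compound 2 to compound 3 (0.13 log units; within the scatter), that is, none beyond the scatter. Compound 3 is therefore estimated at 150 nM in this assay, with a likely range from 60 nM to 400 nM.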

Compound 3, half-maximal inhibitory concentration: 280 nM
Compound 3: middle estimate off by 1.9-fold (0.27 log units), on the low side, and the stated range covers the measured number.
By their numbers in this assay, from the lowest: compounds 2, 1 and 3 (each within the scatter of the next, the first and the last beyond it).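

In this assay, going by these compounds alone, the change on the carbonyl carbon gives a 2.5-fold higher number from compound 2 to compound 3 (0.41 log units; beyond the scatter) and is the first step to rise beyond the scatter, which shows that the aromatic group on this amide can move the number, though only modestly. Within the data shown here, the other new step, a 1.3-fold higher number from compound 1 to compound 3 (0.12 log units; within the scatter), stays within the scatter, so 1-benzofuran-2-yl and 4-fluorophenyl cannot be told apart here, and compound 1 lies within the scatter of both compound 2 and compound 3, leaving only that one pair clearly separated. Nothing available explains why this exchange shifts the number.

The exchange alters several things at once, replacing a six-membered ring that holds nitrogen with a five-membered ring that holds oxygen, so these compounds cannot show whether ring size or the hetero atom matters more; an indol-2-yl group, with nitrogen in the five-membered ring, would bear on that question. Also open, from the compounds shown here alone, is whether an aromatic group is needed on this carbonyl carbon at all, which a saturated ring such as cyclohexyl or a simple alkyl chain would address.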